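This account rests on a few compounds, and the source may have more. Where it says the series, first, only, none or still open, it means among the compounds named here.

Measured in an assay on isolated protein for inhibition of leukotriene B4 receptor 1 (Homo sapiens), tested at 10 uM; on this read-out lower numbers stand for less inhibition and higher numbers for more inhibition at the one concentration tested (going by the name of the read-out):
- compound 1, `C=CCc1cc(C(C)=O)c(O)cc1OCCCCC#N`, gives 92%
- compound 2, `C=CCc1cc(C(C)=O)c(O)cc1OCCCCC`, gives 60%
- compound 3, `C=CCCCCOc1cc(O)c(C(C)=O)cc1CC=C`, gives 73%

Compound 3 stands second highest of the three values. Its nearest neighbour is reached by the step of a number 13 percentage points higher from compound 2 to compound 3 (beyond the scatter), and the top value by a number 19 percentage points lower from compound 1 to compound 3 (beyond the scatter). All three measured steps change the group on the saturated chain carbon four bonds along the chain from the oxygen on the aromatic ring: a number 32 percentage points lower from compound 1 to compound 2 (beyond the scatter) and a number 19 percentage points lower from compound 1 to compound 3 (beyond the scatter) both lower the number when the cyano is exchanged, and a number 13 percentage points higher from compound 2 to compound 3 (beyond the scatter) raises it.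

Compound 4, `C=CCc1cc(C(C)=O)c(O)cc1OCCCCCC(C)(C)O`, differs from compound 3 at the same place: 2-hydroxy-2-methylpropyl in place of vinyl on a saturated chain carbon, four bonds along the chain from an oxygen on an aromatic ring. Among the measured compounds shown here, none of the measured steps puts a group carrying a hydrogen-bond donor or acceptor at this place other than the cyano of compound 1, so no measured step tells directly what this exchange will do in this assay. Given that the three exchanges already seen here all stay within a modest to large band, compound 4 is expected to remain close to compound 3, with an estimated step of a number 5 percentage points higher from compound 3 to compound 4 (within the scatter), which would lie within the scatter. The estimate for compound 4 in this assay is therefore 78%, ranging from 50% to 95%.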

Compound 4, a percentage reported as inhibition, at one concentration (the size of the read-out at that concentration, not a potency): 98%
The estimate for compound 4 lay 20 percentage points below the measured number, and the stated range ends below it.
By their numbers in this assay, from the lowest: compound 2; then compound 3; then compounds 1 and 4 (each within the scatter of the next).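

In this assay, the exchange of vinyl for 2-hydroxy-2-methylpropyl on the saturated chain carbon, four bonds along the chain from the oxygen on the aromatic ring, raises the number well beyond the scatter (a number 25 percentage points higher from compound 3 to compound 4 (beyond the scatter)), and the comparison with the plain pentyl-ended chain gives a still wider gap (a number 38 percentage points higher from compound 2 to compound 4 (beyond the scatter)). Cyano is therefore no longer the only group at this place that lifts the read-out clear of the two hydrocarbon chain ends, since the tertiary alcohol of compound 4 cannot be separated from it (a number 6 percentage points higher from compound 1 to compound 4 (within the scatter)). Nothing available accounts for these shifts in this assay.

Compound 4 changes both the length of the chain and its end group, so the compounds shown do not separate the effect of the hydroxyl from that of the added carbons, and a primary alcohol, a carboxylic acid or an amine at the chain end remains an open case. With compound 1 and compound 4 this close at a single concentration, the read-out also leaves their relative potency unresolved.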